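Indole enone series: nitrogen methyl removal and compound 4

The source may hold more compounds than are shown below. What is called first, only, known or untested is meant among the compounds shown, and "the series" means these compounds.

Values in a functional assay on HCT-8 cells (Homo sapiens) for antiproliferative activity, read by MTT assay, with a stated time of 48 h (a higher number here means a weaker inhibitor, a lower number a stronger inhibitor), for the measured compounds:
compound 1 `COc1cc(C(=O)/C(C)=C/c2c[nH]c3ccccc23)cc([Se]C)c1OC`: 32 nM
compound 2 `COc1cc(C(=O)/C=C/c2cn(C)c3ccccc23)cc(N)c1OC`: 605 nM
compound 3 `COc1cc(C(=O)/C(C)=C/c2cn(C)c3ccccc23)cc([Se]C)c1OC`: 48 nM

Compound 1 and compound 3 share a core and differ in one place, (hydrogen in place of methyl on an aromatic nitrogen). In this assay this gives a 1.5-fold lower number from compound 3 to compound 1 (0.18 log units; within the scatter), so the two values cannot be told apart by this assay.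

Compound 2 stands apart: the difference between its core and the core of compound 3 is not broken down here. What the two values show is that in this assay compound 2 gives 605 nM while compound 3 gives 48 nM, a gap beyond the scatter; the gap to compound 1 is larger still.

Compound 4 `COc1cc(C(=O)/C=C/c2c[nH]c3ccccc23)cc(N)c1OC` is not yet measured. It differs from compound 2 in one place, (hydrogen in place of methyl on an aromatic nitrogen). The place is described in the same words as for the step from compound 3 to compound 1, so this is the same change on a different core.

Within the data shown here, for compound 4 the expectation in this assay is a step of a 1.3-fold lower number from compound 2 to compound 4 (0.13 log units; within the scatter), close to no change, because the one measured instance of this change gave a 1.5-fold lower number from compound 3 to compound 1 (0.18 log units; within the scatter). Among the measured compounds shown here, that this carries over to the core of compound 2 is an assumption, as only one instance is available. Compound 4 is therefore estimated at 450 nM, with a likely range of 200 nM to 1200 nM.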

Compound 4, half-maximal inhibitory concentration: 577 nM
Estimate against measurement, compound 4: 1.3-fold (0.11 log units) below; measured number inside the range.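

In this assay, hydrogen in place of methyl on the aromatic nitrogen gives a 1.0-fold lower number from compound 2 to compound 4 (0.02 log units; within the scatter), and the values of this pair cannot be told apart. Set beside the earlier instance of the same change, the two steps agree: the same change on two cores in this assay, a 1.5-fold lower number (0.18 log units; within the scatter) from compound 3 to compound 1 and a 1.0-fold lower number (0.02 log units; within the scatter) from compound 2 to compound 4, 1.4-fold (0.16 log units) apart, within the scatter of two such steps On these two cores, then, this assay does not detect the exchange of methyl for hydrogen at this nitrogen, and the large gap between the cores remains whichever of the two groups is present; this does not show that the same would hold on a further core, and two steps within the scatter cannot settle whether any real difference lies behind them.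

Left open is whether a group on that nitrogen other than methyl, such as ethyl, a longer chain or an acetyl group, would leave the values of the two cores where they stand. Also open is which of the places separating the core of compound 2 from the core of compound 3 carries the gap between their values; among the compounds shown, none alters one of those places alone.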